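Amide aryl swap toward a methylpyridinyl group

The source may hold more compounds than are shown below. What is called first, only, known or untested is meant among the compounds shown, and "the series" means these compounds.

The measured compounds:
Compound 1, `O=C(COc1ccc2cc(/C=C3/SC(=O)NC3=O)ccc2c1)Nc1ccc([N+](=O)[O-])cc1`: in an assay on isolated protein for inhibition of histone deacetylase 4 (Homo sapiens), with a stated time of 1 h (a higher number here means a weaker inhibitor, a lower number a stronger inhibitor), compound 1 gives 1700 nM.
Compound 2, `Cc1ccc(NC(=O)COc2ccc3cc(/C=C4/SC(=O)NC4=O)ccc3c2)cc1Cl`: in this assay compound 2 gives 1100 nM.

Compound 2 has the lower of the two numbers, yet its nearest neighbour, compound 1, lies within the scatter of it, so the two are not separated by these data. For the measured compounds named here, the only step so far, a 1.5-fold lower number from compound 1 to compound 2 (0.19 log units; within the scatter), exchanges one aryl group for another on the amide-type nitrogen and leaves the read-out essentially where it was. Compound 3, `Cc1cccc(NC(=O)COc2ccc3cc(/C=C4/SC(=O)NC4=O)ccc3c2)n1`, is built on the same core; it differs from compound 2 by 6-methylpyridin-2-yl in place of 3-chloro-4-methylphenyl on an amide-type nitrogen. That single measured step is the one that bears on the new change: both replace the group on the amide-type nitrogen while the rest of the molecule is kept, and it showed no shift beyond the scatter. On that basis a step of a 1.2-fold higher number from compound 2 to compound 3 (0.07 log units; within the scatter) is expected in this assay, that is, none beyond the scatter. Compound 3 is therefore estimated at 1300 nM, with a range from 500 nM to 3500 nM. One prior step is a thin basis, and the entering group brings one hydrogen-bond acceptor where the leaving group had none, so the range is kept wide.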

Compound 3, half-maximal inhibitory concentration: 1100 nM
Compound 3: the middle estimate sits 1.2-fold (0.07 log units) above what was measured, within the range that was stated.
By their numbers in this assay, from the lowest: compounds 2, 3 and 1 (each within the scatter of the next).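

In this assay the group on the amide-type nitrogen now carries a hetero atom in its ring and one hydrogen-bond acceptor, and 6-methylpyridin-2-yl in place of 3-chloro-4-methylphenyl gives no change at the digits printed from compound 2 to compound 3 (within the scatter) with the chlorine gone as well. Set against 4-nitrophenyl, the same entering group gives a 1.5-fold lower number from compound 1 to compound 3 (0.19 log units; within the scatter) so all three pairs now lie within the scatter, and three different aromatic groups at this place are not separated by these data, including one whose ring is not carbon only. Nothing available here accounts for this flat read-out at the amide-type nitrogen.

What the compounds shown leave open is whether this place responds at all to a group of another kind, such as a benzyl group, a piperidine or an aryl ring carrying a carboxylic acid, since only directly attached six-membered aromatic rings appear on the amide-type nitrogen here. They also leave open whether compounds 1, 2 and 3 would stay together against another histone deacetylase.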